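From Benzylamino to Dipropylamino in a Weak Pair

This account rests on a few compounds, and the source may have more. Where it says the series, first, only, none or still open, it means among the compounds named here.

In a functional assay on MCF7 cells (Homo sapiens) for inhibition, read by sulforhodamine B assay (a higher number here means a weaker inhibitor, a lower number a stronger inhibitor), compound 1 (`O=C1C(Nc2ccc(I)cc2)=CC(=O)c2c1nc1n2[C@H]2OC[C@@H](O)[C@H]2OC1`) gives 3890 nM as a measured number. In this assay compound 2 (`O=C1C(NCc2ccccc2)=CC(=O)c2c1nc1n2[C@H]2OC[C@@H](O)[C@H]2OC1`) stands at > 8000 nM and this is a limit of the assay, not a number. Its place is therefore the limit of > 8000 nM in this assay, at which 1 of the 2 values shown sits, and nothing firmer. For the measured compounds named here, the one measured step that bears on the next change is an at least 2.0-fold higher number from compound 1 to compound 2 (0.31 log units; beyond the scatter) and it concerns the group on an amine nitrogen. Compound 3 (`CCCN(CCC)C1=CC(=O)c2c(nc3n2[C@H]2OC[C@@H](O)[C@H]2OC3)C1=O`) carries dipropylamino in place of benzylamino on a double-bonded ring carbon and remains unmeasured. Compound 2 offers only the limit of > 8000 nM as a starting point, so no step beyond the scatter is expected in this assay and compound 3 may also reach that limit. The expected step is an at least 1.1-fold lower number from compound 2 to compound 3 (0.05 log units; that floor lies within the scatter) and it is only an estimate. The estimated value for compound 3 is 7000 nM with an expected range of 2500 nM to 16000 nM for a measured number.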

Compound 3, half-maximal inhibitory concentration: > 16000 nM
Compound 3 gave a limit, no number; the forecaster's own chance of this, stated with the estimate: 40%; at least 2.2-fold (0.35 log units) between middle value and limit.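

In this assay, dipropylamino in place of (4-iodophenyl)amino on a double-bonded ring carbon gives an at least 4.1-fold higher number from compound 1 to compound 3 (0.61 log units; beyond the scatter). The step from compound 2 to compound 3 cannot be read, so benzylamino and dipropylamino cannot be ranked, but a group with no ring and 0 hydrogen-bond donors also fails to give a measured number, which leaves compound 1 as the only one of the three that has one. Compound 3 has a limit of the assay, not a number: the limit of > 16000 nM in this assay, at which 1 of the 3 values shown sits.

The compounds shown leave open whether the iodine matters or only the aromatic ring on the amine nitrogen, which a plain phenylamino group would test. They also leave open whether a short amine such as dimethylamino, or a cyclic amine such as morpholine, on this carbon would return a measured number.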